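The source may hold more compounds than are shown below. What is called first, only, known or untested is meant among the compounds shown, and "the series" means these compounds.

Within the data shown here, compound 3 `C[C@H](NC(=O)[C@]1(Cc2ccccc2)CCN1C(=O)OCc1ccccc1)C(=O)NCc1ccccc1` is the one compound of the three with a number rather than a limit in an ADME assay on HELF cells (Homo sapiens) for cytotoxicity, with a stated time of 3 days; on this read-out higher numbers stand for lower toxicity in this test and lower numbers for higher toxicity in this test: it gives 100000 nM. Compound 2 `CC(C)CNC(=O)[C@H](C)NC(=O)[C@]1(Cc2ccccc2)CCN1C(=O)OCc1ccccc1` reaches only a limit, > 100000 nM. Compound 1 `C[C@H](NC(=O)[C@@]1(Cc2ccccc2)CCN1C(=O)OCc1ccccc1)C(=O)NC(C)(C)C` likewise reaches only a limit, > 100000 nM. Among the measured compounds shown here, the only measured step, a number no higher from compound 2 to compound 3 (the limit leaves the size open), is bounded on one side by the limit of > 100000 nM in this assay, at which 2 of the 3 values shown sit. Compound 4 `C[C@H](NC(=O)[C@]1(Cc2ccccc2)CCN1C(=O)OCc1ccccc1)C(=O)NC(C)(C)C` differs from compound 3 by tert-butyl in place of benzyl on an amide-type nitrogen. For the measured compounds named here, no measured step covers this exchange; compound 1, which carries the same tert-butyl group, shows only its limit. Compound 4 is therefore expected to sit at or near the limit, with an expected step of no change at the digits printed from compound 3 to compound 4 (within the scatter) in this assay. The estimate for compound 4 is 100000 nM, within 50000 nM to 200000 nM.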

Compound 4, minimum cytotoxic concentration: > 100000 nM
Compound 4: a limit, no number; the forecaster's own chance of this, stated with the estimate: 70%; the middle value lies on the limit itself.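

In this assay, tert-butyl in place of benzyl on an amide-type nitrogen gives a number no lower from compound 3 to compound 4 (the limit leaves the size open), so this exchange does not bring the number down. The steps to compound 4 from compound 1 and from compound 2 cannot be read, and compound 4 adds one more limit rather than a number: the limit of > 100000 nM in this assay, at which 3 of the 4 values shown sit. The drawn configuration at the saturated ring carbon therefore leaves no readable difference here: the fact that compounds 1 and 4 differ only in the configuration as drawn.

On these data alone, the size of the exchange stays open while these values remain limits. As far as these compounds go, whether an amine or a carboxylic acid on the amide-type nitrogen would give a number in this assay also stays open.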